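From 6-methoxy-1,3-benzothiazol-2-yl to 1-(pyridin-2-yl)ethyl

The source may hold more compounds than are shown below. What is called first, only, known or untested is meant among the compounds shown, and "the series" means these compounds.

Within the data shown here, in a functional assay for inhibition, with Homo sapiens as the target (a higher number here means a weaker inhibitor, a lower number a stronger inhibitor), compound 2 `COc1ccc2nc(COc3ccc4c(c3)c(SC(C)(C)C)c(CC(C)(C)C(=O)O)n4Cc3ccc(Cl)cc3)sc2c1` gives 8 nM as the only actual number so far. Compound 1 `CCCC(Oc1ccc2c(c1)c(SC(C)(C)C)c(CC(C)(C)C(=O)O)n2Cc1ccc(Cl)cc1)c1ccc2ccccc2n1` gives > 52 nM which is a limit only. Compound 3 `C[C@H](COc1ccc2c(c1)c(SC(C)(C)C)c(CC(C)(C)C(=O)O)n2Cc1ccc(Cl)cc1)c1ccccn1` differs from compound 2 by 1-(pyridin-2-yl)ethyl in place of 6-methoxy-1,3-benzothiazol-2-yl on a saturated chain carbon bound to an oxygen on an aromatic ring with 1-(pyridin-2-yl)ethyl in place of 6-methoxy-1,3-benzothiazol-2-yl on a saturated chain carbon bound to an oxygen on an aromatic ring. Among the measured compounds shown here, no measured step covers this change. A weakening beyond the scatter in this assay is expected, estimated as a 3.8-fold higher number from compound 2 to compound 3 (0.57 log units; beyond the scatter) in size. Compound 3 is expected at 30 nM with 8 nM to 120 nM as the estimated range.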

Compound 3, half-maximal inhibitory concentration: 3 nM
Beside the measured number, compound 3's estimate is 10-fold (1.00 log units) above it; measured number outside the range, below it.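

In this assay, the 6-methoxy-1,3-benzothiazol-2-yl group is not needed on the saturated chain carbon bound to an oxygen on an aromatic ring: 1-(pyridin-2-yl)ethyl in its place gives a 2.7-fold lower number from compound 2 to compound 3 (0.43 log units; beyond the scatter). One six-membered aromatic ring with 1 hetero atom is therefore enough here, with fewer heavy atoms entering than leaving. Compound 1 remains a limit only and gives no step at this position: the limit of > 52 nM in this assay, at which 1 of the 3 values shown sits.

Open, as far as these compounds go, is what the defined stereocentre of 1-(pyridin-2-yl)ethyl contributes. Also open, from the compounds shown here alone, is the role of the ring nitrogen, which a phenyl group in place of the pyridin-2-yl ring would address.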